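A few compounds are considered here, and "the series" means these few. Any claim that something is new, unique, unknown or untested is made for them only; others in the source may bear on it.

Measured so far:
- Compound 1, `C=C1CCCC(C)(C)C1CC[C@]1(C)CC[C@H]([C@@H](C)C(=O)OC)OO1`: in a functional assay on SNB-75 cells (Homo sapiens) for inhibition (a higher number here means a weaker inhibitor of growth, a lower number a stronger inhibitor of growth), compound 1 gives 2670 nM
- Compound 2, `C=C1CCC[C@H]2[C@](C)(CC[C@]3(C)CC[C@@H]([C@@H](C)C(=O)O)OO3)[C@@H](C)CC[C@]12C`: in this assay compound 2 gives 830 nM

Within the data shown here, compound 2 stands at the lower of the two numbers seen in this assay; the only comparison is compound 1, whose higher number lies beyond the scatter of repeated runs, so compound 2 is the stronger inhibitor of growth of the two on the present data. Among the measured compounds shown here, no pair of measured compounds differs in a single place, so no measured step is available to set expectations against.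

Compound 3, `C=C1CCC[C@H]2[C@](C)(CC[C@]3(C)CC[C@H]([C@@H](C)C(=O)O)OO3)[C@@H](C)CC[C@]12C`, is the next entry to be measured in this assay. It differs from compound 2 as follows: the two compounds have the same atoms and bonds and differ only in configuration as drawn: 1 of 7 stereo elements differ; a stereocentre at a saturated ring carbon is drawn S in compound 2 and R in compound 3. Nothing leaves and nothing enters; the change is purely in the drawn configuration at one ring carbon.

With no measured step of this kind in the series, the direction and size of the effect are open. Such an inversion at a ring stereocentre is expected to produce a moderate step, most likely toward a somewhat higher number, but possibly none beyond the scatter. Compound 3 is thus expected to give 1500 nM in this assay, within 300 nM to 6000 nM, which means an expected step of a 1.8-fold higher number from compound 2 to compound 3 (0.26 log units; within the scatter).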

Compound 3, concentration for 50% growth inhibition: 1080 nM
Compound 3: middle estimate off by 1.4-fold (0.14 log units), on the high side; the range from low to high includes it.
By their numbers in this assay, from the lowest: compounds 2 and 3 (each within the scatter of the next); then compound 1.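

In this assay, among these compounds, the inversion at this saturated ring carbon gives a 1.3-fold higher number from compound 2 to compound 3 (0.11 log units; within the scatter) and so supplies the first single-place step. That step lies within the scatter, so on the present data this assay does not separate the S and R drawings at this carbon, and growth inhibition holds up with either configuration while the carboxylic acid and the rest of the structure stay fixed. The reading of this pair rests on a single structural difference, which keeps it clean as a comparison: the fact that compounds 2 and 3 differ only in the configuration as drawn.

Whether the same indifference to configuration at this carbon would hold with a primary amide or a primary alcohol in place of the carboxylic acid remains open, as the compounds shown carry no such group on this core. From the compounds shown here alone, what inverting any other stereo element of compound 2 would do is also open, and a single inversion at one carbon gives no basis for expecting the same flat result elsewhere in the structure.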